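The compounds below may be only part of what the source reports. "The series", "measured", "known", "first", "only" and "open" are said of these compounds alone.

Compound 1 `Cc1ccc(-c2nnc(SCCCN3CCN(c4nc5ccccc5o4)CC3)o2)cc1` gives 100000 nM in a functional assay on A-431 cells (Homo sapiens) for inhibition, read by MTT assay, with a stated time of 72 h; on this read-out lower numbers stand for stronger inhibition and higher numbers for weaker inhibition. Among the three measured compounds it stands second highest: compound 2 `Clc1ccc(-c2nnc(SCCCN3CCN(c4nc5ccccc5o4)CC3)o2)cc1` gives 89600 nM and compound 3 `Fc1ccc(-c2nnc(SCCCN3CCN(c4nc5ccccc5o4)CC3)o2)cc1` gives 136000 nM, both within the scatter of compound 1. Compound 4 `Brc1ccc(-c2nnc(SCCCN3CCN(c4nc5ccccc5o4)CC3)o2)cc1` differs from compound 1 in one place: bromo in place of methyl on an aromatic carbon. Two measured steps replace the same methyl by a halogen, a 1.1-fold lower number from compound 1 to compound 2 (0.05 log units; within the scatter) and a 1.4-fold higher number from compound 1 to compound 3 (0.13 log units; within the scatter), and the step between the two halogens, a 1.5-fold higher number from compound 2 to compound 3 (0.18 log units; within the scatter), is likewise within the scatter. None of these exchanges moved the number beyond the scatter, so the exchange for bromo is expected to leave it essentially unchanged, an expected step of no change at the digits printed from compound 1 to compound 4 (within the scatter). Compound 4 is therefore estimated at 100000 nM, with a range from 50000 nM to 200000 nM.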

Compound 4, half-maximal inhibitory concentration: 57800 nM
Estimate against measurement, compound 4: 1.7-fold (0.24 log units) above; the range from low to high includes it.
By their numbers in this assay, from the lowest: compounds 4, 2, 1 and 3 (each within the scatter of the next, the first and the last beyond it).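

Bromo in place of fluoro at this position is the only exchange among these compounds to pass the usual scatter in this assay, with a 2.4-fold lower number from compound 3 to compound 4 (0.37 log units; beyond the scatter). The separation holds against fluoro alone, since a 1.7-fold lower number from compound 1 to compound 4 (0.24 log units; within the scatter) and a 1.6-fold lower number from compound 2 to compound 4 (0.19 log units; within the scatter) both stay within the scatter. Nothing available accounts for the gap between bromo and fluoro. The compounds shown carry only methyl and halogens at this position. As far as these compounds go, whether an amine, a methoxy or a carboxylic acid there would move the number beyond the scatter of compound 1 stays open.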